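The compounds below may be only part of what the source reports. "The series", "measured", "known", "first", "only" and "open" are said of these compounds alone.

Working notes on the series. Compound 1 `CCNC(=O)c1nnn(-c2cc(C(C)C)c(O)cc2O)c1-c1ccc(CN2CCCC(O)C2)cc1` gives in a functional assay on NCI-H460 cells (Homo sapiens) for inhibition, read by sulforhodamine B assay, with a stated time of 72 h (a higher number here means a weaker inhibitor, a lower number a stronger inhibitor), a value of 62 nM, the highest of the two numbers recorded so far. Compound 2 `CCNC(=O)c1nnn(-c2cc(C(C)C)c(O)cc2O)c1-c1ccc(CN2CCCC2)cc1` gives 3 nM in this assay. Going by the values given here, the only measured step, a 21-fold lower number from compound 1 to compound 2 (1.32 log units; beyond the scatter), shows that exchanging the amine on the saturated chain carbon bound to an aromatic carbon can shift the number a long way in this assay.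

Compound 3 `CCNC(=O)c1nnn(-c2cc(C(C)C)c(O)cc2O)c1-c1ccc(CNC2CCN(C)CC2)cc1` is not yet measured. Its change from compound 1 is (1-methylpiperidin-4-yl)amino in place of 3-hydroxypiperidin-1-yl on a saturated chain carbon bound to an aromatic carbon. The step to compound 2 is the only one that bears on this change: it also removes the 3-hydroxypiperidin-1-yl from the same place, and it was large and downward. The entering (1-methylpiperidin-4-yl)amino differs from pyrrolidin-1-yl, so the size cannot be carried over directly, but a step beyond the scatter toward a lower number is the more likely outcome. For compound 3 the number expected in this assay is 20 nM, within a range of 4 nM to 100 nM. This expectation corresponds to a step of a 3.1-fold lower number from compound 1 to compound 3 (0.49 log units; beyond the scatter).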

Compound 3, half-maximal inhibitory concentration: > 1000 nM
Compound 3 gave a limit, no number; the forecaster's own chance of this, stated with the estimate: 0%; at least 50-fold (1.69 log units) between middle value and limit.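

In this assay compound 3 gives a limit and not a number: the limit of > 1000 nM in this assay, at which 1 of the 3 values shown sits. The new steps show that the amine on this saturated chain carbon bound to an aromatic carbon can move the number upward as well as downward, with an at least 16-fold higher number from compound 1 to compound 3 (1.20 log units; beyond the scatter) and an at least 330-fold higher number from compound 2 to compound 3 (2.52 log units; beyond the scatter). Losing 3-hydroxypiperidin-1-yl therefore does not by itself bring a lower number: pyrrolidin-1-yl and (1-methylpiperidin-4-yl)amino replace the same group and the steps run in opposite directions, so the outcome at this place depends on the group that enters.

The compounds shown do not separate the parts of (1-methylpiperidin-4-yl)amino, so it stays open whether the upward step goes with the amine hydrogen on the chain, the methyl on the ring nitrogen or the second ring nitrogen itself. From the compounds shown here alone, it also stays open where simple groups on the same carbon, such as piperidin-1-yl, morpholin-4-yl or dimethylamino, would fall relative to compound 2 and compound 3.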